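This account rests on a few compounds, and the source may have more. Where it says the series, first, only, none or still open, it means among the compounds named here.

Of the compounds shown here, three built on one shared core have been tested in an assay on CHO cells for displacement of a labelled ligand from adenosine receptor A1 (Homo sapiens), read by scintillation counting, with a stated time of 120 min, tested at 10 uM; on this read-out higher numbers stand for more inhibition at the one concentration tested (going by the name of the read-out) and lower numbers for less inhibition. Compound 1 `Nc1scc(CN2CCN(c3ccncc3)CC2)c1C(=O)c1ccc(Cl)cc1` gives 1%. Compound 2 `Nc1scc(CN2CCN(c3cccc(F)c3)CC2)c1C(=O)c1ccc(Cl)cc1`, which carries 3-fluorophenyl in place of pyridin-4-yl on an amine nitrogen in a ring, gives 1%, and the step of no change at the digits printed from compound 1 to compound 2 (within the scatter). Compound 3 `Nc1scc(CN2CCN(c3c(F)cccc3F)CC2)c1C(=O)c1ccc(Cl)cc1`, with 2,6-difluorophenyl on that same amine nitrogen, gives 1%. Its steps of no change at the digits printed from compound 1 to compound 3 (within the scatter) and no change at the digits printed from compound 2 to compound 3 (within the scatter). Compound 3 therefore stands level with compounds 1 and 2: all three show almost no displacement of the labelled ligand at the single concentration tested.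

Compound 4 `Nc1scc(CN2CCN(CCCc3ccc(Cl)cc3)CC2)c1C(=O)c1ccc(Cl)cc1` differs from compound 3 in one place: 3-(4-chlorophenyl)propyl in place of 2,6-difluorophenyl on an amine nitrogen in a ring. The aromatic ring is no longer attached directly to the ring nitrogen but is carried on a propyl chain.

For the measured compounds named here, none of the measured steps bears directly on this kind of change, since each of them exchanges one aromatic group for another on that nitrogen, and every one stayed within the scatter. Nothing in the data points to a gain from the new group. The expected step is a number 4 percentage points higher from compound 3 to compound 4 (within the scatter), that is, no change beyond the scatter. Compound 4 is thus estimated to give 5%, with a range from -8% to 25%.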

Compound 4, a percentage reported as inhibition, at one concentration (the size of the read-out at that concentration, not a potency): 0%
Beside the measured number, compound 4's estimate is 5 percentage points above it, and the stated range covers the measured number.
By their numbers in this assay, from the lowest: compounds 4, 1, 2 and 3 (each within the scatter of the next).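

Setting the aromatic ring on a propyl chain, rather than directly on the amine nitrogen in a ring, gives in this assay a number 1 percentage points lower from compound 3 to compound 4 (within the scatter) and, against the other two groups, a number 1 percentage points lower from compound 2 to compound 4 (within the scatter) and a number 1 percentage points lower from compound 1 to compound 4 (within the scatter). For the compounds shown here, this widens what the earlier compounds showed: they covered only aromatic groups bound directly to that nitrogen, whereas a group with more heavy atoms, a chain and a chlorine in place of fluorine also leaves the four compounds inseparable, all with almost no displacement at the single concentration tested. No measurement offered here gives a reason for this flat result.

Still open, as far as these compounds go, is whether a different kind of group on this nitrogen, such as a propyl chain ending in an amine or a carboxylic acid, or a benzyl group with its shorter link, would produce clear displacement. Also open, from the compounds shown here alone, is what a change elsewhere on the shared core would do, for example a methoxy group in place of the chlorine on the chlorophenyl ketone, which all four compounds keep unchanged.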